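A few compounds are considered here, and "the series" means these few. Any claim that something is new, unique, unknown or untested is made for them only; others in the source may bear on it.

- Compound 1 `CC1(C)OCc2c(Nc3n[nH]c4ccccc34)nc(-c3cn[nH]c3)nc21` gives 6 L/kg
- Compound 2 `CC1(C)OCc2c(Nc3n[nH]c4ccc(F)cc34)nc(-c3cn[nH]c3)nc21` gives 6.8 L/kg
- Compound 3 `CC1(C)OCc2c(Nc3n[nH]c4c(C(F)(F)F)cccc34)nc(-c3cn[nH]c3)nc21` gives 2.4 L/kg

In an ADME assay on the whole organism for pharmacokinetics, with Rattus norvegicus as the target (on this read-out lower numbers stand for narrower distribution and higher numbers for wider distribution into tissues), compound 1 sits within the scatter of compound 2, while compound 3 lies clearly lower. Compound 4 `CC1(C)OCc2c(Nc3n[nH]c4cc(C(F)(F)F)ccc34)nc(-c3cn[nH]c3)nc21` is still unmeasured. It differs from compound 1 by one change, (trifluoromethyl in place of hydrogen on an aromatic carbon), with trifluoromethyl in place of hydrogen on an aromatic carbon. For the measured compounds named here, the closest precedent is the same swap at a different aromatic carbon, a 2.5-fold lower number from compound 1 to compound 3 (0.40 log units; beyond the scatter), a modest step. The fluoro swap, a 1.1-fold higher number from compound 1 to compound 2 (0.05 log units; within the scatter), involves a different group and bears less on this change. Going by the values given here, with only one direct precedent, the expected outcome is a similar modest fall, an estimated 1.8-fold lower number from compound 1 to compound 4 (0.26 log units; within the scatter) overall. Compound 4 is expected at 3.3 L/kg (range 1.7 L/kg to 6.2 L/kg) in this assay.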

Compound 4, volume of distribution at steady state: 1.2 L/kg
Compound 4: the middle estimate sits 2.8-fold (0.44 log units) above what was measured; measured number below the stated range.
By their numbers in this assay, from the lowest: compounds 4 and 3 (each within the scatter of the next); then compounds 1 and 2 (each within the scatter of the next).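

In this assay trifluoromethyl at this place, on the six-membered aromatic ring of carbon only, brings a 5.0-fold lower number from compound 1 to compound 4 (0.70 log units; beyond the scatter) and so lowers the number beyond the scatter, as the same swap did at the other aromatic carbon in compound 3. Compound 3 and compound 4 lie within the scatter of each other, so these numbers do not tell the two places apart. No measurement shown here gives a reason for the fall. The compounds shown leave open whether fluoro at this same place, or an amine or a carboxylic acid there, would lower the number as well.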